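Bromo for hydrogen on the fused ring: compound 3

The source may hold more compounds than are shown below. What is called first, only, known or untested is meant among the compounds shown, and "the series" means these compounds.

Measured so far in an assay on isolated protein for inhibition of Amine oxidase [flavin-containing] B (Homo sapiens), read by fluorescence, with a stated time of 15 min; on this read-out lower numbers stand for stronger inhibition and higher numbers for weaker inhibition:
compound 1, `COc1ccc(/C=C/c2cc(OC)cc(OC)c2/C=C/C(=O)c2cc3ccccc3oc2=O)cc1`, gives 9170 nM
compound 2, `COc1ccc(/C=C/c2cc(OC)cc(OC)c2/C=C/C(=O)c2cc3cc(OC)ccc3oc2=O)cc1`, gives only a limit, > 60000 nM

Within the data shown here, compound 1 is the only member with a number in this assay; the other value shown is a limit. For compound 2 this assay reports a limit and no number. Among the measured compounds shown here, the one measured step, an at least 6.5-fold higher number from compound 1 to compound 2 (0.81 log units; beyond the scatter), rests on that limit of > 60000 nM in this assay, at which 1 of the 2 values shown sits, and therefore fixes only a floor for its size.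

Compound 3 `COc1ccc(/C=C/c2cc(OC)cc(OC)c2/C=C/C(=O)c2cc3ccc(Br)cc3oc2=O)cc1` differs from compound 1 by bromo in place of hydrogen on an aromatic carbon. The methoxy step bears on it only loosely: the entering group is different and its place on the fused ring is different, so the size seen there is no direct guide. That step is beyond the scatter; whether a bromo at another place behaves alike is open. For compound 3 a modest rise in the number is expected, a 1.6-fold higher number from compound 1 to compound 3 (0.21 log units; within the scatter), short of the floor the methoxy step showed. Compound 3 is estimated at 15000 nM in this assay, with a range from 4500 nM to 50000 nM. A limit instead of a number for compound 3 cannot be ruled out.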

Compound 3, half-maximal inhibitory concentration: 55300 nM
Compound 3: the middle estimate sits 3.7-fold (0.57 log units) below what was measured; the measured number lies above the stated range.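

In this assay, a single bromo in place of hydrogen on an aromatic carbon of the fused ring system is enough for a 6.0-fold higher number from compound 1 to compound 3 (0.78 log units; beyond the scatter), so this position does not accept the change as a neutral swap. Among these compounds, this is the first step with a number at both ends, which lets its size be read directly, whereas the methoxy step, an at least 6.5-fold higher number from compound 1 to compound 2 (0.81 log units; beyond the scatter), ends in a limit and fixes only a floor: the limit of > 60000 nM in this assay, at which 1 of the 3 values shown sits. Two different groups at two different places on the fused ring now both raise the number from compound 1, a pattern that rests on compound 2 and compound 3 alone, with neither going against it.

It remains open whether the rise belongs to the bromo or to its place on the fused ring, as no pair shown holds one fixed while varying the other. Also open, on these data alone, is whether a fluoro, an amine or a carboxylic acid at this position would keep the number close to that of compound 1, 9170 nM, or raise it in the same way.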